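A Methoxyphenyl Swap Under the Cytotoxicity Ceiling

A few compounds are considered here, and "the series" means these few. Any claim that something is new, unique, unknown or untested is made for them only; others in the source may bear on it.

Compound 1 `Cc1ccc(-c2cn(C/C=C3\OC(=O)C(OCc4ccccc4)=C3OCc3ccccc3)nn2)cc1` was tested in an ADME assay on HFF cells (Homo sapiens) for cytotoxicity, read by MTT assay, with a stated time of 72 h; a higher number here means a weaker inhibitor, a lower number a stronger inhibitor. There compound 1 gives > 100000 nM, which is a limit of the assay and not a number; the limit of > 100000 nM in this assay, at which 2 of the 3 values shown sit, shows where it sits. Compound 3 `O=C1O/C(=C\Cn2cc(-c3cc(C(F)(F)F)cc(C(F)(F)F)c3)nn2)C(OCc2ccccc2)=C1OCc1ccccc1` gives > 100000 nM, again a limit. Compound 2 `O=C1O[C@H]([C@@H](O)Cn2cc(-c3cccc(O)c3)nn2)C(OCc2ccccc2)=C1OCc1ccccc1` gives a measured value of 39000 nM in this assay. Compound 4 `COc1ccccc1-c1cn(C/C=C2\OC(=O)C(OCc3ccccc3)=C2OCc2ccccc2)nn1` has not yet been measured. It differs from compound 1 by 2-methoxyphenyl in place of 4-methylphenyl on an aromatic carbon. No step between measured compounds connects this kind of change to any shift in this assay, so the numbers shown give no size for it. Only a small shift, if any, is expected here: a number no higher from compound 1 to compound 4 (the limit leaves the size open). Compound 4 is expected to give about 100000 nM, between 40000 nM and 300000 nM, most likely reported once more as a limit.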

Compound 4, half-maximal inhibitory concentration: > 100000 nM
Compound 4 gave a limit, no number; the forecaster's own chance of this, stated with the estimate: 70%; the middle value lies on the limit itself.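

Among the compounds shown here, compound 1 and compound 4 each give only a limit of the assay and not a number, so no step between them can be read. In this assay the compounds shown leave open how far 2-methoxyphenyl in place of 4-methylphenyl shifts the value, if at all.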